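This account rests on a few compounds, and the source may have more. Where it says the series, first, only, none or still open, it means among the compounds named here.

Compound 1 `Cc1oc2c3c(ccc2c(=O)c1-c1ccccc1)OC[C@H]1[C@@H]3C2=C(CCCC2=O)OC1(C)C`: > 100000 nM
Compound 2 `Cc1oc2c3c(ccc2c(=O)c1C)OC[C@H]1[C@@H]3C2=C(CC(C)(C)CC2=O)OC1(C)C`: > 100000 nM

Both of these have been tested in an ADME assay on MRC5 cells (Homo sapiens) for antiproliferative activity, read by MTT assay, with a stated time of 48 h; on this read-out higher numbers stand for weaker inhibition and lower numbers for stronger inhibition. In this read-out compound 1 returns only a limit of the assay, > 100000 nM, not a number. Compound 2 likewise returns only a limit, > 100000 nM. Where compound 2 stands among the values shown is therefore easy to say: every measured result sits at the limit of > 100000 nM in this assay, at which 2 of the 2 values shown sit, so no compound can be ranked against another, and no step between measured compounds exists.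

Compound 3 `Cc1coc2c3c(ccc2c1=O)OC[C@H]1[C@@H]3C2=C(CC(C)(C)CC2=O)OC1(C)C` has not yet been measured in this assay. It differs from compound 2 by hydrogen in place of methyl on an aromatic carbon, in words, hydrogen in place of methyl on an aromatic carbon. Within the data shown here, because of the limit of > 100000 nM in this assay, at which 2 of the 2 values shown sit, no measured step offers a size to compare with. The step is expected to be no larger than the scatter, a number no higher from compound 2 to compound 3 (the limit leaves the size open), in no particular direction. Compound 3 is estimated at 100000 nM, in a range from 30000 nM to 300000 nM, and the assay is expected most likely to report only a limit for it again.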

Compound 3, half-maximal inhibitory concentration: > 100000 nM
Compound 3 gave a limit, no number; the forecaster's own chance of this, stated with the estimate: 80%; the middle value sits exactly at the limit.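

Compound 3 gives > 100000 nM as a limit of the assay, not a number. No step can be read from compound 2 to compound 3, with hydrogen in place of methyl, because both results are limits: the limit of > 100000 nM in this assay, at which 3 of the 3 values shown sit. The compounds shown leave open whether any compound of this kind gives an actual number in this assay at all, and therefore how any change in structure affects the result.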